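Dropping the Chlorine: What Compound 3 Might Show

The compounds below may be only part of what the source reports. "The series", "measured", "known", "first", "only" and "open" are said of these compounds alone.

Compound 2 `Cc1cc(OCC2=NCCO2)ccc1Cl` was tested in a toxicity assay on the whole organism with Rattus norvegicus as the target, at a dose of 400 mg/kg by the oral route (on this read-out lower numbers stand for a weaker effect and higher numbers for a stronger effect at the one dose given), where compound 2 gives 100%. Among the two compounds measured this is the highest number, but its nearest neighbour lies within the scatter: compound 1 `Clc1ccc(OCC2=NCCO2)cc1` gives 90% in this assay, and the step of a number 10 percentage points higher from compound 1 to compound 2 (within the scatter) is too small to count as a real difference. Compound 3 `Cc1cccc(OCC2=NCCO2)c1` has not yet been measured. It differs from compound 2 in one place: hydrogen in place of chloro on an aromatic carbon. Going by the values given here, no measured step removes a chloro group, so the only guidance is that the single measured step, methyl in place of hydrogen, moved nothing beyond the scatter, and that both measured compounds sit high on the scale. With compound 2 at 100%, the step of a number 20 percentage points lower from compound 2 to compound 3 (beyond the scatter) is expected to be a modest fall with wide uncertainty. Compound 3 is therefore expected to give 80%, most likely between 50% and 100%.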

Compound 3, a percentage reported as activity, at one dose (the size of the read-out at that dose, not a potency): 90%
Estimate against measurement, compound 3: 10 percentage points below, within the range that was stated.
By their numbers in this assay, from the lowest: compounds 1, 3 and 2 (each within the scatter of the next).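

Going from a chloro group to hydrogen on this aromatic carbon, ortho to a methyl group and para to a group of 7 heavy atoms, gives a number 10 percentage points lower from compound 2 to compound 3 (within the scatter) in this assay. The earlier compounds shown here showed only a methyl step, whereas this pair shows that, with the methyl group in place, the high read-out at this one dose does not depend on the chloro group. Nothing measured here gives a reason for this result.

From the compounds shown here alone, it remains open whether a different group on this carbon, such as an amine, a carboxylic acid or a longer chain, would give a number beyond the scatter of compound 2. A single dose also leaves open how these compounds would compare at lower doses, where their read-outs might separate.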